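The compounds below may be only part of what the source reports. "The series", "measured", "known", "first", "only" and "open" are said of these compounds alone.

Compound 1 `O=c1n(Cc2cc3cnccc3n2CCCC(F)(F)F)c2cnccc2n1C1CC1`: in an ADME assay on HeLa cells (Homo sapiens) for cytotoxicity, read by ATP content, with a stated time of 3 days (a lower number here means that less compound is tolerated, a higher number that more compound is tolerated), compound 1 gives > 50000 nM, a limit of the assay rather than a number.
Compound 2 `O=c1n(Cc2cc3cc(Cl)ccc3n2CCCCF)c2cnccc2n1C1CC1`: compound 2 gives > 50000 nM, again a limit.
Compound 3 `O=c1n(Cc2cc3cc(Cl)ccc3n2CCCC(F)(F)F)c2cnccc2n1C1CC1`: compound 3 gives > 50000 nM, also a limit.

Compound 1 therefore stands at the top of what this assay can report, and it is not alone there: the limit of > 50000 nM in this assay, at which 3 of the 3 values shown sit. No measured compound in this set has shown a readable cytotoxic concentration.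

Compound 4 `O=c1n(Cc2cc3cnccc3n2CCCCF)c2cnccc2n1C1CC1` differs from compound 1 in one place: fluoromethyl in place of trifluoromethyl on a saturated chain carbon, three bonds along the chain from an aromatic nitrogen. Within the data shown here, the same exchange, run in the opposite direction, is the only measured step in the set, a step that the two limits leave unreadable from compound 2 to compound 3. Both of its ends are limits, so its size cannot be read. There is thus no measured evidence that this exchange moves cytotoxicity in either direction, and the expectation is that compound 4 stays where compound 1 stands.

Compound 4 is estimated at 50000 nM, within 25000 nM to 100000 nM. The expected step is a number no higher from compound 1 to compound 4 (the limit leaves the size open), which means no change beyond the scatter.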

Compound 4, half-maximal cytotoxic concentration: > 50000 nM
Compound 4 ended at the assay's limit (the forecaster's own chance of this, stated with the estimate: 85%); the middle value lies on the limit itself.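

No step can be read between compound 1 and compound 4, because both sit at a limit of this assay rather than at a number: the limit of > 50000 nM in this assay, at which 4 of the 4 values shown sit. Still open is the concentration at which any of these compounds harms the cells, and whether exchanging trifluoromethyl for fluoromethyl shifts it.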